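Methyl on the aromatic oxygen: one step across two cores

This account rests on a few compounds, and the source may have more. Where it says the series, first, only, none or still open, it means among the compounds named here.

Measured so far in a functional assay on LOX IMVI cells (Homo sapiens) for inhibition, read by sulforhodamine B assay, with a stated time of 48 h, tested at 10 uM; on this read-out lower numbers stand for a stronger effect and higher numbers for a weaker effect at the one concentration tested:
compound 1 `O=C(Nc1cccc(-n2cc(-c3ccncc3)c(-c3cc(O)cc(Cl)c3)n2)c1)Nc1ccc(Cl)c(C(F)(F)F)c1` gives 2.08%
compound 2 `COc1cc(Cl)cc(-c2nn(-c3cccc(NC(=O)Nc4ccc(Cl)c(C(F)(F)F)c4)c3)cc2-c2ccncc2)c1` gives 4.81%
compound 3 `O=C(Nc1cccc(-n2cc(-c3ccncc3)c(-c3cc(O)cc(Cl)c3)n2)c1)c1cc(C(F)(F)F)cc(C(F)(F)F)c1` gives 10.5%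

Compound 1 and compound 2 share one core and differ in a single place: methyl in place of hydrogen on an oxygen on an aromatic ring. Across this pair the read-out moves by a number 2.7 percentage points higher from compound 1 to compound 2 (within the scatter), so the change leaves the result essentially where it was. Compound 3 stands on a second core; how the core of compound 3 differs from the core of compound 1 is not broken down here. The numbers for compound 3, compound 2 and compound 1 all lie within the scatter of one another, so no order among the three is read from them; all three show strong inhibition at the single concentration tested.

Compound 4 `COc1cc(Cl)cc(-c2nn(-c3cccc(NC(=O)c4cc(C(F)(F)F)cc(C(F)(F)F)c4)c3)cc2-c2ccncc2)c1` has not been measured. It differs from compound 3 by methyl in place of hydrogen on an oxygen on an aromatic ring, which is the same change as from compound 1 to compound 2, made at the same kind of place on the same kind of oxygen. The step from compound 3 to compound 4 in this assay is expected to be a number 2.5 percentage points higher from compound 3 to compound 4 (within the scatter). This expectation rests on the measured pair compound 1 to compound 2, where the step was a number 2.7 percentage points higher from compound 1 to compound 2 (within the scatter). Compound 4 is therefore estimated at 13%, with a range from 4% to 24%.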

Compound 4, a percentage reported as activity, at one concentration (the size of the read-out at that concentration, not a potency): 76.1%
Compound 4: the middle estimate sits 63.1 percentage points below what was measured; measured number outside the range, above it.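

In this assay, going from hydroxy to methoxy on the 3-chloro-5-hydroxyphenyl group gives a number 65.6 percentage points higher from compound 3 to compound 4 (beyond the scatter), so on the core of compound 3 this single change removes most of the inhibition seen at the one concentration tested. The change therefore does not carry over from one core to the other with a single size of effect: the same change on two cores in this assay, a number 2.7 percentage points higher (within the scatter) from compound 1 to compound 2 and a number 65.6 percentage points higher (beyond the scatter) from compound 3 to compound 4, 62.9 percentage points apart, beyond the scatter of two such steps. These two pairs show that, for these compounds, the outcome of the methyl cannot be read from one core to the other, but they do not show which feature of the cores is responsible, how the change would behave on any further core, or whether the effect would be stronger or weaker at other concentrations, as each number comes from a single concentration in one cell line.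

Still open, from the compounds shown here alone, is whether the large step on the core of compound 3 follows from the added methyl itself or from the loss of the hydrogen on the oxygen. An amine or a fluorine in place of the hydroxy, or an ethoxy as a longer chain on the oxygen, on both cores would help separate these two readings.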